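The compounds below may be only part of what the source reports. "The series", "measured", "known", "first", "only" and "open" are said of these compounds alone.

In a functional assay on MKN-45 cells (Homo sapiens) for inhibition, read by CCK-8 assay, with a stated time of 24 h (a higher number here means a weaker inhibitor, a lower number a stronger inhibitor), compound 1 (`O=C1Nc2ccc(F)cc2C1=Cc1ccc(-c2cn(-c3ccccc3)nn2)cc1`) gives 11100 nM as its reading. Compound 3 (`O=C1Nc2ccc(F)cc2/C1=C/c1ccc(-c2cn(-c3cccc(F)c3)nn2)cc1`) gives 8190 nM and lies within the scatter of compound 1, so the two are not separated. Compound 2 (`Cc1ccc(-n2cc(-c3ccc(/C=C4\C(=O)Nc5ccc(F)cc54)cc3)nn2)cc1`) gives 34600 nM as its reading, a higher number than that of compound 1 and a gap beyond the scatter.

Compound 4 (`N#Cc1ccc(-n2cc(-c3ccc(C=C4C(=O)Nc5ccc(F)cc54)cc3)nn2)cc1`) has yet to be measured. It differs from compound 1 by cyano in place of hydrogen on an aromatic carbon, para to a large group, so that phenyl becomes 4-cyanophenyl (cyano in place of hydrogen on an aromatic carbon).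

Among the measured compounds shown here, one measured step bears on this change: a 4.2-fold lower number from compound 2 to compound 3 (0.63 log units; beyond the scatter) with 3-fluorophenyl in place of 4-methylphenyl on an aromatic nitrogen. That step is modest but beyond the scatter, and it shows that substitution on this phenyl can move the number. For the measured compounds named here, no measured compound carries cyano, so the data give a rough size but no direction. The working expectation is no shift beyond the scatter, with a modest move either way still possible. The expected change is a 1.2-fold higher number from compound 1 to compound 4 (0.07 log units; within the scatter) as estimated here.

Compound 4 is estimated at 13000 nM within an expected range from 5000 nM to 35000 nM in this series.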

Compound 4, half-maximal inhibitory concentration: > 20000 nM
Compound 4 ended at the assay's limit; the forecaster's own chance of this, stated with the estimate: 5%; middle value at least 1.5-fold (0.18 log units) from the limit.
By their numbers in this assay, from the lowest: compounds 3 and 1 (each within the scatter of the next); then compound 2.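

In this assay compound 4 gives > 20000 nM, which is a limit of the assay and not a number, and it is the only compound of the set to end there: the limit of > 20000 nM in this assay, at which 1 of the 4 values shown sits.

Among the compounds shown here, the change reads as an at least 1.8-fold higher number from compound 1 to compound 4 (0.25 log units; that floor lies within the scatter), so the floor alone does not separate the two compounds, but cyano in this place shows no sign of a lower number, a direction the earlier compounds could not give. With 4-methylphenyl in this place, compound 2 gives 34600 nM, a higher number than compound 1 by a gap beyond the scatter, so neither methyl nor cyano here has yet improved on the plain phenyl.

On these data alone, how far the true reading of compound 4 lies past the limit remains open, and with it any order between compound 4 and compound 2. Also open, as far as these compounds go, is whether an amine or a carboxylic acid in the same place would give a lower number than the plain phenyl, and whether fluoro in this same place would read as the 3-fluorophenyl of compound 3 does.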